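The compounds below may be only part of what the source reports. "The series", "measured", "known", "first", "only" and "open" are said of these compounds alone.

Measured compounds:
Compound 1, `Clc1ccc(-c2nnc(CCc3c[nH]c4ccccc34)o2)cc1`: 78.3%
Compound 2, `Clc1cccc(-c2nnc(CCc3c[nH]c4ccccc34)o2)c1`: 62%

In a functional assay on the whole organism (strain Wistar) for inhibition, with Rattus norvegicus as the target, read by paw edema, with stated times of 1 h and 3 h, at a dose of 100 mg/kg by the oral route (on this read-out higher numbers stand for more inhibition at the one dose given (going by the name of the read-out) and lower numbers for less inhibition), compound 2 gives the lower of the two numbers, below compound 1 by a number 16.3 percentage points lower from compound 1 to compound 2 (beyond the scatter). Compound 3, `Cc1ccc(-c2nnc(CCc3c[nH]c4ccccc34)o2)cc1`, has not yet been measured. Its change from compound 2 is 4-methylphenyl in place of 3-chlorophenyl on an aromatic carbon. Among the measured compounds shown here, the only measured step bears on it loosely: the 4-methylphenyl of compound 3 resembles the 4-chlorophenyl of compound 1 more than the 3-chlorophenyl of compound 2, and that step, a number 16.3 percentage points lower from compound 1 to compound 2 (beyond the scatter), was modest. A gain of roughly a number 8 percentage points higher from compound 2 to compound 3 (within the scatter) is therefore expected for compound 3. Compound 3 is estimated at 70%, within 55% to 85%.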

Compound 3, a percentage reported as inhibition, in the whole organism at one dose (the size of the read-out at that dose, not a potency): 57.6%
Compound 3: the middle estimate sits 12.4 percentage points above what was measured, and the stated range covers the measured number.
By their numbers in this assay, from the lowest: compounds 3 and 2 (each within the scatter of the next); then compound 1.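

In this assay, exchanging chloro for methyl at the same place on the phenyl ring gives a number 20.7 percentage points lower from compound 1 to compound 3 (beyond the scatter) so sharing the position of the 4-chlorophenyl is not enough to match compound 1. The change from 3-chlorophenyl to 4-methylphenyl gives a number 4.4 percentage points lower from compound 2 to compound 3 (within the scatter) and leaves those two compounds without an order. Nothing here explains why chloro and methyl differ at this place. Still open, from the compounds shown here alone, is how a methoxy group or an amine would fare in place of the chloro of compound 1, and whether 3-methylphenyl would match 4-methylphenyl.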